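The source may report more compounds than this note shows. Statements on the series, on what has been measured and on what is new or still open speak of the compounds shown alone.

Compound 1 `Cn1ncc2c(=O)n(-c3ccccc3)c(SC(C)(C)c3ccccc3)nc21` gives 1900 nM in an assay on isolated protein for inhibition of aldehyde dehydrogenase 1A1 (Homo sapiens); a lower number here means a stronger inhibitor, a higher number a weaker inhibitor.
Compound 2 `C[C@@H](Sc1nc2c(cnn2C)c(=O)n1-c1ccccc1)c1ccccc1` gives 70 nM in this assay.

Among the measured compounds shown here, of these two numbers in this assay, compound 2 holds the lower one; the only measured step, a 27-fold lower number from compound 1 to compound 2 (1.43 log units; beyond the scatter), is large and concerns the group attached to the sulfur. Compound 3 `CC(Sc1nc2c(cnn2C)c(=O)n1-c1ccccc1)c1ccccn1` differs from compound 2 in one place: 1-(pyridin-2-yl)ethyl in place of 1-phenylethyl on a sulfur. For the measured compounds named here, no measured pair swaps the ring of carbon only for a ring with one hetero atom, so the step from compound 1 to compound 2, which removes one methyl at the carbon next to the sulfur, does not speak directly to this change. Without such a comparison, compound 3 is expected to sit close to compound 2, with a step of a 1.4-fold higher number from compound 2 to compound 3 (0.15 log units; within the scatter), which would not reach beyond the scatter. For compound 3 the estimated value is 100 nM, in a range from 30 nM to 350 nM.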

Compound 3, half-maximal inhibitory concentration: 242 nM
For compound 3 the middle estimate is 2.4-fold (0.38 log units) below the measured one; measured number inside the range.
By their numbers in this assay, from the lowest: compound 2; then compound 3; then compound 1.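

In this assay the ring on the group attached to the sulfur proves to matter as well as the extra methyl seen earlier: 1-(pyridin-2-yl)ethyl in place of 1-phenylethyl gives a 3.5-fold higher number from compound 2 to compound 3 (0.54 log units; beyond the scatter). Compound 3 still keeps much of the gain over the bulkier starting group, with a 7.9-fold lower number from compound 1 to compound 3 (0.89 log units; beyond the scatter), although that step changes both the ring and the methyl count. The 1-phenylethyl group of compound 2 has a defined stereocentre and the group in compound 3 is not drawn with one, so the ring change cannot be separated from that difference.

Nothing available explains why the number rises with this change. Also open, going by these compounds, is how this position would respond to 1-(pyridin-4-yl)ethyl, or to an amine or a carboxylic acid on the ring.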